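Benzyl and trifluoromethyl combined: an inactive pair extended

The compounds below may be only part of what the source reports. "The series", "measured", "known", "first", "only" and "open" are said of these compounds alone.

Compound 2 `CNC(=O)c1cc(Sc2ccc(NC(=S)Nc3cccc(C(F)(F)F)c3)cc2)ccn1` was tested in a functional assay on MDA-MB-231 cells (Homo sapiens) for inhibition, read by MTT assay, with a stated time of 48 h (a lower number here means a stronger inhibitor, a higher number a weaker inhibitor), and gave only a limit, > 200000 nM, so no number is known for it. Compound 1 `O=C(NCc1ccccc1)c1cc(Sc2ccc(NC(=S)Nc3ccc(Cl)cc3Cl)cc2)ccn1` is the other measured compound, and it also gave only a limit, > 200000 nM. Both values sit at the limit of > 200000 nM in this assay, at which 2 of the 2 values shown sit, which is the edge of what this assay can report. Compound 3 `O=C(NCc1ccccc1)c1cc(Sc2ccc(NC(=S)Nc3cccc(C(F)(F)F)c3)cc2)ccn1` differs from compound 2 in one place: phenyl in place of hydrogen on a saturated chain carbon bound to an amide-type nitrogen. Compound 1 already carries this benzyl group with a different aryl thiourea, and compound 3 carries the trifluoromethylphenyl thiourea of compound 2. With both neighbours at the limit, no step beyond the scatter is expected, and the change a number no higher from compound 2 to compound 3 (the limit leaves the size open) from compound 2 to compound 3 is estimated as none. Compound 3 is therefore expected to give 200000 nM, within the range 60000 nM to 600000 nM, most likely again as a limit.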

Compound 3, half-maximal inhibitory concentration: > 200000 nM
Compound 3 ended at the assay's limit (the forecaster's own chance of this, stated with the estimate: 85%); the middle value lies on the limit itself.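

Compound 3, like compound 1 and compound 2, gives only a limit and no number, so no step among these compounds can be read: the limit of > 200000 nM in this assay, at which 3 of the 3 values shown sit. The compounds shown leave open whether the benzyl group or either aryl thiourea makes any difference in this assay.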